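Ester series: removing the phenyl of compound 3

The source may report more compounds than this note shows. Statements on the series, on what has been measured and on what is new or still open speak of the compounds shown alone.

Three compounds have numbers in an assay on membranes from cerebellum for inhibition of Fatty-acid amide hydrolase 1 (Rattus norvegicus); on this read-out higher numbers stand for weaker inhibition and lower numbers for stronger inhibition. Compound 1 `CCCCC/C=C\C/C=C\C/C=C\C/C=C\CCCC(=O)OCC1COC(C)(C)O1` gives 98000 nM and compound 2 `CCCCC/C=C\C/C=C\C/C=C\C/C=C\CCCC(=O)OC[C@@H]1COC(C)(C)O1` gives 17000 nM; the step of a 5.8-fold lower number from compound 1 to compound 2 (0.76 log units; beyond the scatter) is tied to the fact that one of compounds 1 and 2 is drawn with a defined configuration and the other without, at the place where they differ. Compound 3 `O=C(OCC1CCCCO1)c1ccc(-c2ccccc2)cc1` gives 32000 nM and stands second highest of the three, with compound 2 nearest and compound 1 furthest; against compound 1 the gap lies beyond the scatter, against compound 2 within it.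

Compound 4 `O=C(OCC1CCCCO1)c1ccccc1` differs from compound 3 by hydrogen in place of phenyl on an aromatic carbon, the phenyl leaving an aromatic carbon of a six-membered aromatic ring of carbon only, para to a large group. Among the measured compounds shown here, the single measured step, a 5.8-fold lower number from compound 1 to compound 2 (0.76 log units; beyond the scatter), concerns a drawn configuration at a saturated ring carbon and does not bear on loss of an aromatic ring; no measured step does. The expectation is therefore set near compound 3, with a wide range and leaning to a higher number. Compound 4 is expected to give 60000 nM, between 20000 nM and 200000 nM. The expected step is a 1.9-fold higher number from compound 3 to compound 4 (0.27 log units; within the scatter).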

Compound 4, half-maximal inhibitory concentration: 53000 nM
Estimate against measurement, compound 4: 1.1-fold (0.05 log units) above; the measured number falls inside the stated range.
By their numbers in this assay, from the lowest: compounds 2, 3, 4 and 1 (each within the scatter of the next, the first and the last beyond it).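

In this assay, hydrogen in place of phenyl on an aromatic carbon, para to a large group, gives a step within the scatter (a 1.7-fold higher number from compound 3 to compound 4 (0.22 log units; within the scatter)). Among the compounds shown here, this is the only reading so far at this position, and it gives no sign that the phenyl, with its six-membered aromatic ring of carbon only, matters to this read-out: the pair cannot be told apart here. For the compounds shown here, the one piece of evidence at hand concerns a drawn configuration elsewhere, and nothing available bears on this step.

As far as these compounds go, whether an amine or a carboxylic acid on the same aromatic carbon would separate from hydrogen and phenyl remains open. So does whether an amide in place of the ester link would shift the number beyond the scatter.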